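Amine variation in the side chain series

The source may report more compounds than this note shows. Statements on the series, on what has been measured and on what is new or still open speak of the compounds shown alone.

Among the measured compounds shown here, compound 3 `COc1cc2ccc(=O)oc2cc1OCC(O)CN1CCCCC1` stands highest of the three numbers measured so far in a functional assay on HUVEC cells (Homo sapiens) for inhibition, read by MTT assay, with a stated time of 24 h, tested at 100 uM; on this read-out lower numbers stand for less inhibition of growth and higher numbers for more inhibition of growth at the one concentration tested; in it compound 3 gives 80.7%. Its nearest neighbour is compound 2 `COc1cc2ccc(=O)oc2cc1OCCCCBr`, which in this assay gives 16.9%, and the furthest is compound 1 `COc1cc2ccc(=O)oc2cc1OCC(O)CN1CCCC1`, which gives 0.3%. For the measured compounds named here, the only single-point step among the measured compounds is a number 80.4 percentage points higher from compound 1 to compound 3 (beyond the scatter), a change confined to the amine carried on a saturated chain carbon, two bonds along the chain from an oxygen on a saturated carbon.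

Compound 4 `CCN(CC)CC(O)COc1cc2oc(=O)ccc2cc1OC` is not yet measured. It differs from compound 3 by diethylamino in place of piperidin-1-yl on a saturated chain carbon, two bonds along the chain from an oxygen on a saturated carbon. Going by the values given here, the sole measured step that bears on this change is the one from pyrrolidin-1-yl to piperidin-1-yl, and it shows that exchanging the amine at this place moves the read-out far beyond the scatter. Among the compounds with values here, whether opening the ring to diethylamino points upward or downward is settled by no measured pair; compound 2 carries no amine and is no guide. A large step is therefore expected here, uncertain in sign and estimated on balance as a number 35.7 percentage points lower from compound 3 to compound 4 (beyond the scatter). Compound 4 is expected to give 45%, within a range from 10% to 85%.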

Compound 4, percent growth inhibition at one concentration: 0.3%
Beside the measured number, compound 4's estimate is 44.7 percentage points above it, and the stated range ends above it.
By their numbers in this assay, from the lowest: compounds 1 and 4 (each within the scatter of the next); then compound 2; then compound 3.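

In this assay the first measured open-chain amine at this place does not keep the high reading of the piperidin-1-yl group: diethylamino in place of piperidin-1-yl gives a number 80.4 percentage points lower from compound 3 to compound 4 (beyond the scatter) and leaves the read-out far down. The comparison with the pyrrolidin-1-yl group gives no change at the digits printed from compound 1 to compound 4 (within the scatter) in the same assay, so a ring at this place does not by itself separate the amines, since a ring amine and an open-chain amine read alike here while compound 3 stands apart from both. Among these three amines the high reading therefore belongs to the piperidin-1-yl group alone, and no measurement offered here accounts for this.

The compounds shown leave open whether the high reading extends to other six-membered ring amines such as morpholin-4-yl or 4-methylpiperazin-1-yl, or to the larger azepan-1-yl ring, at this same place. They also leave open whether the hydroxyl group on the chain is needed for the reading of compound 3, which a piperidin-1-yl analogue on a plain butyl chain would test directly.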